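Vero cell tolerance: from compound 1 to compound 3

The source may hold more compounds than are shown below. What is called first, only, known or untested is meant among the compounds shown, and "the series" means these compounds.

The series is read in an ADME assay on Vero cells (Chlorocebus sabaeus) for cytotoxicity, read by MTT assay, with a stated time of 72 h; a higher number here means that more compound is tolerated, a lower number that less compound is tolerated. Compound 1 `CCOC(=O)c1c(-c2ccc(OC)cc2)oc2ccc(OCCCN3C(=O)C(=O)c4cc(F)ccc43)cc12` gives 256000 nM and stands at the low end of the two numbers shown; compound 2 `CCOC(=O)c1c(-c2ccc(F)cc2)oc2ccc(OCCCN3C(=O)C(=O)c4cc(F)ccc43)cc12` gives 512000 nM, and a 2.0-fold higher number from compound 1 to compound 2 (0.30 log units; within the scatter). Compound 3 `CCOC(=O)c1c(-c2ccc(OC)cc2)oc2ccc(OCCCCN3C(=O)C(=O)c4ccccc43)cc12` differs from compound 1 by a group of 12 heavy atoms (9 carbon, 1 nitrogen, 2 oxygen; one five-membered non-aromatic ring with 1 hetero atom, one six-membered aromatic ring of carbon only) in place of a group of 12 heavy atoms (8 carbon, 1 nitrogen, 2 oxygen, 1 fluorine; one five-membered non-aromatic ring with 1 hetero atom, one six-membered aromatic ring of carbon only), on a saturated chain carbon, three bonds along the chain from an oxygen on an aromatic ring. For the measured compounds named here, no measured step touches this part of the molecule; the only step known, from compound 1 to compound 2, concerns a different ring and stayed within the scatter. No movement beyond the scatter is therefore expected in this assay . For compound 3 the estimated value is 256000 nM, with a range of 128000 nM to 512000 nM, which is expected to mean no change at the digits printed from compound 1 to compound 3 (within the scatter).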

Compound 3, half-maximal cytotoxic concentration: > 1020000 nM
Compound 3: only a limit was reported; the forecaster's own chance of this, stated with the estimate: 20%; middle value at least 3.9-fold (0.60 log units) from the limit.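

In this assay, the position on a saturated chain carbon, three bonds along the chain from an oxygen on an aromatic ring, gives a step beyond the scatter: an at least 3.9-fold higher number from compound 1 to compound 3 (0.60 log units; beyond the scatter). The earlier change on the other ring gave only a 2.0-fold higher number from compound 1 to compound 2 (0.30 log units; within the scatter). Compound 3 gives > 1020000 nM, which is a limit and not a number: the limit of > 1020000 nM in this assay, at which 1 of the 3 values shown sits.

The group that enters differs from the one that leaves by 9 carbon against 8 carbon and 1 fluorine, and the compounds shown do not separate these two differences. From the compounds shown here alone, how an amine or a longer chain at this place would read in this assay stays open.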